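The compounds below may be only part of what the source reports. "The series", "measured", "known", "first", "only" and "open" are said of these compounds alone.

Measured compounds:
- compound 1, `Cc1nnc(SCC(=O)Nc2ccc(-c3nc(-c4ccccc4)c(-c4ccccc4)n3C)cc2)s1`, 34.8%
- compound 2, `Cn1ccnc1SCC(=O)Nc1ccc(-c2nc(-c3ccccc3)c(-c3ccccc3)n2C)cc1`, 13.6%
- compound 3, `Cn1c(-c2ccc(NC(=O)CN3CCN(c4ccccc4)CC3)cc2)nc(-c2ccccc2)c1-c1ccccc1`, 17.3%

In a functional assay on HT-29 cells (Homo sapiens) for cytotoxicity, read by MTT assay, with a stated time of 24 h, tested at 0.64 ug/mL (a higher number here means a stronger effect of the compound at the concentration tested, a lower number a weaker effect), compound 3 stands second highest of the three numbers. Its nearest neighbour is compound 2, and the two values lie within the scatter of each other; compound 1 is furthest, as the step of a number 17.5 percentage points lower from compound 1 to compound 3 (beyond the scatter) shows, while a number 3.7 percentage points higher from compound 2 to compound 3 (within the scatter) is within the scatter. Compound 4, `COc1ccc(CN2CCN(CC(=O)Nc3ccc(-c4nc(-c5ccccc5)c(-c5ccccc5)n4C)cc3)CC2)cc1`, is not yet measured. It differs from compound 3 in one place: 4-methoxybenzyl in place of phenyl on an amine nitrogen in a ring. Among the compounds with values here, none of the measured steps touches the group on that ring nitrogen; the steps from compound 1 and compound 2 to compound 3 only exchange the whole linker for the 4-phenylpiperazin-1-yl group, so they give no direct guide to swapping phenyl for 4-methoxybenzyl. Within the data shown here, with no step that bears on this change, no movement beyond the scatter is expected, and the estimated step is a number 0.7 percentage points higher from compound 3 to compound 4 (within the scatter). For compound 4 the expected value in this assay is therefore 18%, with an estimated range from 5% to 35%.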

Compound 4, a percentage reported as activity, at one concentration (the size of the read-out at that concentration, not a potency): 5.2%
Beside the measured number, compound 4's estimate is 12.8 percentage points above it; the range from low to high includes it.
By their numbers in this assay, from the lowest: compounds 4, 2 and 3 (each within the scatter of the next, the first and the last beyond it); then compound 1.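

In this assay, within the data shown here, the step of a number 12.1 percentage points lower from compound 3 to compound 4 (beyond the scatter) is the first to show that the read-out responds to the group on the amine nitrogen in the ring, since the earlier steps exchanged the whole group on the saturated chain carbon. The change brings in more heavy atoms and one hydrogen-bond acceptor, but the carbon of the benzyl and the methoxy arrive together, so the step cannot be assigned to either one alone. Nothing measured here gives a reason for this step.

The compounds shown leave open how plain benzyl or 4-methoxyphenyl on that nitrogen would compare with phenyl and 4-methoxybenzyl. They also leave open whether a small alkyl group such as methyl or an acetyl group there would give a similar read-out.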